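A trifluoromethoxy group on compound 1

This account rests on a few compounds, and the source may have more. Where it says the series, first, only, none or still open, it means among the compounds named here.

- compound 1 `c1ccc(-c2ccc(-c3ccc(-c4nc5ccccc5[nH]4)cc3)cc2)cc1`: 100000 nM
- compound 2 `Cc1ccc2[nH]c(-c3ccc(-c4ccc(-c5ccc(N(C)C)cc5)cc4)cc3)nc2c1`: 6240 nM
- compound 3 `Cc1ccc2[nH]c(-c3ccc(-c4ccc(-c5cccc(Cl)c5)cc4)cc3)nc2c1`: 2120 nM

In a functional assay on Gurav cells (Homo sapiens) for inhibition, read by sulforhodamine B assay (on this read-out lower numbers stand for stronger inhibition of growth and higher numbers for weaker inhibition of growth), compound 1 has the highest number of the three, beyond the scatter from both others. Compound 4 `FC(F)(F)Oc1ccc(-c2ccc(-c3ccc(-c4nc5ccccc5[nH]4)cc3)cc2)cc1` carries trifluoromethoxy in place of hydrogen on an aromatic carbon, para to a large group (trifluoromethoxy in place of hydrogen on an aromatic carbon). Within the data shown here, no measured step isolates this change. The only one, a 2.9-fold lower number from compound 2 to compound 3 (0.47 log units; beyond the scatter), replaces 4-(dimethylamino)phenyl with 3-chlorophenyl and is modest. Compound 2 gives 6240 nM and compound 3 gives 2120 nM, both far lower than compound 1, though each differs from it in more than one place. A clearly lower number is therefore expected, the estimated step being a 13-fold lower number from compound 1 to compound 4 (1.10 log units; beyond the scatter). For compound 4 the estimate is 8000 nM, with an expected range of 2000 nM to 40000 nM.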

Compound 4, concentration for 50% growth inhibition: 100000 nM
Compound 4: middle estimate off by 13-fold (1.10 log units), on the low side; the measured number lies above the stated range.
By their numbers in this assay, from the lowest: compound 3; then compound 2; then compounds 1 and 4 (each within the scatter of the next).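

In this assay the step reads no change at the digits printed from compound 1 to compound 4 (within the scatter) for trifluoromethoxy in place of hydrogen on an aromatic carbon, para to a large group. Among these compounds, this is the first measured step to isolate a change at this place, and it shows that this group, added alone to the core of compound 1, leaves the number where it stood. From the compounds shown here alone, whether an amine or a hydroxyl group at the same place would give a lower number remains open. No measurement shown here offers an explanation for this result.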